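A few compounds are considered here, and "the series" means these few. Any claim that something is new, unique, unknown or untested is made for them only; others in the source may bear on it.

Compound 1 `CC[C@@H](Nc1c(C#N)c(-c2ccc(-c3ccccc3N(C)C)cc2)nc2cnccc12)C(N)=O`: 3.2
Compound 2 `CC[C@@H](Nc1c(C#N)c(-c2ccc(-c3cccnc3C)cc2)nc2cnccc12)C(N)=O`: 1.9

In a physicochemical assay for lipophilicity, read by HPLC, at pH 7.5 (a higher number here means a more lipophilic compound, a lower number a more polar compound), compound 2 is the lower of the two measured compounds at 1.9, and compound 1 stands at 3.2. Compound 3 `CC[C@@H](Nc1c(C#N)c(-c2ccc(-c3cccc(Cl)c3)cc2)nc2cnccc12)C(N)=O` has 3-chlorophenyl in place of 2-methylpyridin-3-yl on an aromatic carbon. Among the compounds with values here, only one measured step bears on this change. That step, a number 1.30 log units lower from compound 1 to compound 2 (beyond the scatter), is large and brought in the group that now leaves. A large rise is therefore expected, though one step is thin evidence. The expected change is a number 1.60 log units higher from compound 2 to compound 3 (beyond the scatter). Compound 3 is estimated at 3.5, with an expected range of 2.9 to 4.1.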

Compound 3, distribution coefficient: 3.1
The estimate for compound 3 lay 0.40 log units above the measured number; measured number inside the range.
By their numbers in this assay, from the lowest: compound 2; then compounds 3 and 1 (each within the scatter of the next).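

In this assay, 3-chlorophenyl on this aromatic carbon, para to a large group, gives a number 1.20 log units higher from compound 2 to compound 3 (beyond the scatter) as a large step, so the number moves strongly in both directions at this one place. Two quite different substituted phenyl groups also read alike, with a number 0.10 log units lower from compound 1 to compound 3 (within the scatter) as the step between them, leaving compound 2, with its pyridine ring, alone at the low end among these three. Nothing measured here gives a reason for these numbers.

Still open, on these data alone, is how plain phenyl or an unmethylated pyridin-3-yl would read, which would help separate the effect of the ring nitrogen from that of the methyl. As far as these compounds go, the effect of moving the chlorine elsewhere on the ring, as in 4-chlorophenyl, also remains open.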